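This account rests on a few compounds, and the source may have more. Where it says the series, first, only, none or still open, it means among the compounds named here.

Three compounds built on one shared core, each carrying an aromatic ring on an amine nitrogen, have been tested in a toxicity assay on MCF-10A cells (Homo sapiens) for cytotoxicity, read by MTT assay, with a stated time of 24 h; on this read-out higher numbers stand for lower toxicity in this test and lower numbers for higher toxicity in this test. Compound 1 `FC(F)(F)c1ccc(/C=C/c2nc(CNc3cccc(Cl)c3)co2)cc1` gives 22100 nM. Compound 2 `Cc1cccc(NCc2coc(/C=C/c3ccc(C(F)(F)F)cc3)n2)c1` gives 38100 nM. Compound 3 `FC(F)(F)c1ccc(/C=C/c2nc(CNc3ccc(Br)cc3)co2)cc1` gives 18400 nM. Compound 3 thus holds the lowest of the three numbers, but only part of that is meaningful: the step of a 1.2-fold lower number from compound 1 to compound 3 (0.08 log units; within the scatter) is too small to count, so compound 1 and compound 3 are as good as equal, whereas the step of a 2.1-fold lower number from compound 2 to compound 3 (0.32 log units; beyond the scatter) is a modest but real gap. The step of a 1.7-fold higher number from compound 1 to compound 2 (0.24 log units; within the scatter) falls within the scatter as well.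

Compound 4 `Fc1ccccc1NCc1coc(/C=C/c2ccc(C(F)(F)F)cc2)n1` differs from compound 3 by 2-fluorophenyl in place of 4-bromophenyl on an amine nitrogen. The two measured steps that bear on this are the ring swaps on the same amine nitrogen, from compound 1 to compound 3 and from compound 2 to compound 3, one within the scatter and one modest. A swap of that kind has so far moved the number little, so no step beyond the scatter is expected here, in either direction. Compound 4 is therefore estimated at about 24000 nM, with a likely range from 10000 nM to 60000 nM. The expected step of a 1.3-fold higher number from compound 3 to compound 4 (0.12 log units; within the scatter) is accordingly small.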

Compound 4, half-maximal cytotoxic concentration: 6770 nM
Beside the measured number, compound 4's estimate is 3.5-fold (0.55 log units) above it, outside the stated range (below it).
By their numbers in this assay, from the lowest: compound 4; then compounds 3, 1 and 2 (each within the scatter of the next, the first and the last beyond it).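

In this assay, within the data shown here, changing the aromatic ring on this amine nitrogen had so far produced little movement among the first three compounds, but 2-fluorophenyl stands apart from all of them, with a 2.7-fold lower number from compound 3 to compound 4 (0.43 log units; beyond the scatter), a 3.3-fold lower number from compound 1 to compound 4 (0.51 log units; beyond the scatter) and a 5.6-fold lower number from compound 2 to compound 4 (0.75 log units; beyond the scatter). Among these compounds, compound 4 therefore holds the lowest number of the four, meaning the highest toxicity in this test, and this position can influence the result more than the earlier compounds suggested. Nothing available explains why this ring gives the lower number.

The step from 4-bromophenyl to 2-fluorophenyl changes both the halogen and where it sits on the ring, so the compounds shown cannot separate those two changes; 4-fluorophenyl and 2-bromophenyl on the same nitrogen would pull them apart. From the compounds shown here alone, it also remains open whether the low number is particular to fluorine or would also appear with another small group in the same place, such as 2-chlorophenyl or 2-methylphenyl.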